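Notes on the step from compound 2 to compound 4

The source may hold more compounds than are shown below. What is called first, only, known or untested is meant among the compounds shown, and "the series" means these compounds.

Measured so far in an ADME assay on TERT-RPE1 cells (Homo sapiens) for cytotoxicity, read by MTT assay, with a stated time of 72 h (a lower number here means a stronger inhibitor, a higher number a weaker inhibitor), for three compounds:
compound 1 `COc1ccc(/C=C2/CN(C)/C(=N/c3ccc(C(F)(F)F)cc3)S2)cc1` gives 72000 nM
compound 2 `COc1ccc(/C=C2\S/C(=N\c3ccc(C(C)(C)C)cc3)N(C)C2=O)cc1` gives 46700 nM
compound 3 `C=CC/N=C1/NCC(=C)S1` gives > 100000 nM (a limit)

The value for compound 3 is a limit of the assay and not a number. That leaves two numbers in the series. Compound 2 at 46700 nM and compound 1 at 72000 nM lie within the scatter of each other, so neither can be placed ahead of the other.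

Compound 4 `COc1ccc(/C=C2\S/C(=N\c3ccccc3)N(C)C2=O)cc1` has hydrogen in place of the tert-butyl of compound 2 on an aromatic carbon, para to a large group (hydrogen in place of tert-butyl on an aromatic carbon). Going by the values given here, no measured pair shows this change. With compound 2 at 46700 nM as the starting point, a small step towards a higher number in this assay is expected, probably none beyond the scatter. The estimated change is a 1.3-fold higher number from compound 2 to compound 4 (0.11 log units; within the scatter) and remains an expectation. For compound 4 the expected value is 60000 nM with an estimated range from 28000 nM to 100000 nM at the upper end.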

Compound 4, half-maximal inhibitory concentration: > 100000 nM
Compound 4: a limit, no number; the forecaster's own chance of this, stated with the estimate: 25%; at least 1.6-fold (0.22 log units) between middle value and limit.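

Hydrogen in place of tert-butyl on an aromatic carbon, para to a large group, gives in this assay an at least 2.1-fold higher number from compound 2 to compound 4 (0.33 log units; beyond the scatter), the first step in the series that can be read at all, so this position is not indifferent to the change. Compound 4 gives > 100000 nM, which is a limit of the assay and not a number. The step therefore has a lower bound but no measured size, since the series runs into the top of the measurable range: the limit of > 100000 nM in this assay, at which 2 of the 4 values shown sit.

At this position the compounds shown compare only tert-butyl and hydrogen. As far as these compounds go, whether a smaller alkyl group such as methyl, an amine or a carboxylic acid there would give a number or also reach the limit remains open.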